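The compounds below may be only part of what the source reports. "The series", "measured", "known", "first", "only" and "open" are said of these compounds alone.

Measured so far in an assay on isolated protein for inhibition of tyrosine-protein kinase receptor UFO (Homo sapiens), read by ELISA, with a stated time of 1 h; on this read-out lower numbers stand for stronger inhibition and higher numbers for weaker inhibition:
- compound 1 `COc1cc2nccc(Oc3ccc(NS(=O)(=O)c4c(F)cccc4F)c(F)c3)c2cc1OC`, which in this assay gives > 1000 nM, a limit of the assay rather than a number.
- compound 2 `COc1cc2nccc(Oc3ccc(NS(=O)(=O)c4ccccc4Cl)c(F)c3)c2cc1OC`, which in this assay gives > 1000 nM, likewise a limit.

For the measured compounds named here, compound 2 therefore stands at the limit of > 1000 nM in this assay, at which 2 of the 2 values shown sit, and the one measured step, a step that the two limits leave unreadable from compound 1 to compound 2, cannot be read. Compound 3 `COc1cc2nccc(Oc3ccc(NS(=O)(=O)c4ccc(F)c(Cl)c4)c(F)c3)c2cc1OC` differs from compound 2 by 3-chloro-4-fluorophenyl in place of 2-chlorophenyl on a sulfonyl sulfur. Going by the values given here, no measured step bears readably on this change, so no shift beyond the scatter in this assay is expected, and compound 3 is expected to stay near the limit. The estimate for compound 3 is 3000 nM, between 800 nM and 20000 nM, an expected step that the limit leaves unreadable from compound 2 to compound 3.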

Compound 3, half-maximal inhibitory concentration: > 1000 nM
Compound 3: a limit, no number (the forecaster's own chance of this, stated with the estimate: 75%); the middle value does not contradict the limit.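

No step from compound 1 to compound 3 or from compound 2 to compound 3 can be read, because all three compounds give only a limit: the limit of > 1000 nM in this assay, at which 3 of the 3 values shown sit.

The compounds shown leave open how strongly each one inhibits, and whether any group on the sulfonyl sulfur changes that.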